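The compounds below may be only part of what the source reports. "The series", "measured", "known", "first", "only" and "open" are said of these compounds alone.

Measured in a functional assay on MCF7 cells (Homo sapiens) for antiproliferative activity (on this read-out higher numbers stand for weaker inhibition and lower numbers for stronger inhibition), so far:
Compound 1 (`CC(C)=CCc1cc(C(=O)Nc2cc3ccc(OCCCN4CCCC4)c(C)c3oc2=O)ccc1O`) gives 990 nM
Compound 2 (`CCCNCCCOc1ccc2cc(NC(=O)c3ccc(O)c(CC=C(C)C)c3)c(=O)oc2c1C`) gives 980 nM
Compound 3 (`CC(C)=CCc1cc(C(=O)Nc2cc3ccc(OCCCNCC(=O)O)c(C)c3oc2=O)ccc1O`) gives 18100 nM

Compound 3 has the highest number of the three and is the weakest here. Compound 4 (`CC(C)=CCc1cc(C(=O)Nc2cc3ccc(OCCCN[C@H](C)c4ccccc4)c(C)c3oc2=O)ccc1O`) has 1-phenylethyl in place of carboxymethyl on an amine nitrogen. Going by the values given here, no measured compound carries 1-phenylethyl. Two large steps bear on this change, an 18-fold higher number from compound 1 to compound 3 (1.26 log units; beyond the scatter) and an 18-fold higher number from compound 2 to compound 3 (1.27 log units; beyond the scatter), and both end at the carboxymethyl compound. The third, a 1.0-fold lower number from compound 1 to compound 2 (0.00 log units; within the scatter), leaves the two amines unseparated. With carboxymethyl gone, a step of similar size towards a lower number is expected, estimated as a 23-fold lower number from compound 3 to compound 4 (1.35 log units; beyond the scatter) in this assay. The estimate for compound 4 is 800 nM with an expected range from 250 nM to 2500 nM on this read-out.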

Compound 4, half-maximal inhibitory concentration: 1450 nM
Estimate against measurement, compound 4: 1.8-fold (0.26 log units) below; the range from low to high includes it.
By their numbers in this assay, from the lowest: compounds 2, 1 and 4 (each within the scatter of the next); then compound 3.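

In this assay, 1-phenylethyl in place of carboxymethyl on the amine nitrogen gives a 12-fold lower number from compound 3 to compound 4 (1.10 log units; beyond the scatter), showing that the change away from carboxymethyl need not lead to a propyl or pyrrolidin-1-yl amine. The added six-membered aromatic ring and defined stereocentre leave compound 4 unseparated from the smaller amines, with a 1.5-fold higher number from compound 2 to compound 4 (0.17 log units; within the scatter) and a 1.5-fold higher number from compound 1 to compound 4 (0.17 log units; within the scatter). Nothing available here explains why carboxymethyl stands apart.

Still open, on these data alone, is how the mirror-image 1-phenylethyl group or a plain benzyl group would read on this nitrogen. Also open, as far as these compounds go, is whether a methyl ester of the carboxylic acid in compound 3 would read like the acid or like the amines.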